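Swapping an amide for a pyrimidine on the ring nitrogen

The compounds below may be only part of what the source reports. "The series", "measured", "known", "first", "only" and "open" are said of these compounds alone.

Of the compounds shown here, three sharing one core have been measured in an assay on blood for inhibition of Indoleamine 2,3-dioxygenase 1 (Homo sapiens); a higher number here means a weaker inhibitor, a lower number a stronger inhibitor. Compound 1 `C[C@@H](C(=O)Nc1ccc(F)cc1)C1CCC2C(CCCN2C(=O)c2cccc(Cl)c2)C1` gives 0.13 nM; "not determined" (no result reported) (2 entries) in this assay; its several entries there, (the several entries of compound 1 in this assay, 0.13 nM; "not determined" (no result reported) (2 entries)), show that one of its entries reports no result. Compound 2 `O=C(c1cccc(Cl)c1)N1CCCC2CC(C3(C(=O)Nc4ccc(F)cc4)CCC3)CCC21` gives 0.98 nM. Compound 3 `O=C(C1CC1)N1CCCC2CC(C3(C(=O)Nc4ccc(F)cc4)CCC3)CCC21` gives 0.86 nM. The step of a 1.1-fold lower number from compound 2 to compound 3 (0.06 log units; within the scatter) changes a 3-chlorophenyl on a carbonyl carbon to a cyclopropyl, and the two values sit within the usual scatter of each other, so compound 3 and compound 2 cannot be told apart on these numbers.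

Compound 4 `Cc1nccc(N2CCCC3CC(C4(C(=O)Nc5ccc(F)cc5)CCC4)CCC32)n1` is not yet measured. It differs from compound 3 by 2-methylpyrimidin-4-yl in place of cyclopropylcarbonyl on an amine nitrogen in a ring. Among the measured compounds shown here, the only measured step, from compound 2 to compound 3, stayed on a carbonyl and hardly moved the number; the change to compound 4 removes the carbonyl altogether and puts an aromatic ring directly on the nitrogen, a larger change for which no measured step exists. A modest weakening is therefore expected, and the estimated step of a 2.3-fold higher number from compound 3 to compound 4 (0.37 log units; beyond the scatter) reflects that guess. Compound 4 is estimated at 2 nM, within a range from 0.4 nM to 10 nM.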

Compound 4, half-maximal inhibitory concentration: 0.29 nM
The estimate for compound 4 lay 6.9-fold (0.84 log units) above the measured number; the measured number lies below the stated range.
By their numbers in this assay, from the lowest: compound 4; then compounds 3 and 2 (each within the scatter of the next).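

On the amine nitrogen in the ring, a carbonyl is not needed for a low number in this assay: 2-methylpyrimidin-4-yl in place of cyclopropylcarbonyl gives a 3.0-fold lower number from compound 3 to compound 4 (0.47 log units; beyond the scatter), and in place of (3-chlorophenyl)carbonyl it gives a 3.4-fold lower number from compound 2 to compound 4 (0.53 log units; beyond the scatter). The two carbonyl-linked groups could not be told apart, so this swap is the only change at this position shown here that moves the number beyond the scatter, and a six-membered aromatic ring set directly on the nitrogen does better than either of them. Nothing measured here bears on why the number falls with this change.

A single pyrimidine cannot show which part of it matters, and a plain phenyl, a pyridin-4-yl or a pyrimidin-4-yl without the methyl on the same nitrogen would begin to separate the ring, its nitrogens and the methyl. On these data alone, whether the swap would act in the same way on compound 1, which differs from compound 2 in another place, also stays open.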